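A few compounds are considered here, and "the series" means these few. Any claim that something is new, unique, unknown or untested is made for them only; others in the source may bear on it.

Measured compounds in an assay for inhibition of Fatty-acid amide hydrolase 1 (Rattus norvegicus); a higher number here means a weaker inhibitor, a lower number a stronger inhibitor:
- compound 1 `COC(=O)c1ccc(CCCCCCC(=O)c2ncc(-c3ccccn3)o2)cc1` gives 1.5 nM
- compound 2 `O=C(CCCCCCc1ccccn1)c1ncc(-c2ccccn2)o1` gives 120 nM
- compound 3 `O=C(CCCCCCc1cccnc1)c1ncc(-c2ccccn2)o1` gives 32 nM

Compound 3 stands second highest of the three numbers in this assay; its nearest neighbour is compound 2, and compound 1 lies far below it. Within the data shown here, the one step that has been measured, a 3.8-fold lower number from compound 2 to compound 3 (0.57 log units; beyond the scatter), exchanges one pyridyl isomer for another on the saturated chain.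

Compound 4 `O=C(O)c1ccc(CCCCCCC(=O)c2ncc(-c3ccccn3)o2)cc1` is obtained from compound 3 by the change (4-carboxyphenyl in place of pyridin-3-yl on a saturated chain carbon, six bonds along the chain from a carbonyl carbon). Among the measured compounds shown here, no measured step covers this exchange of an aryl group for a carboxyphenyl, so the pyridyl-isomer step gives only a sense of how sensitive this position is. For the measured compounds named here, compound 1 and compound 3 show that an ester-bearing phenyl at this position gives a markedly lower number than the pyridin-3-yl of compound 3, but no step between them is on record and the acid of compound 4 is not the ester of compound 1. Compound 4 is therefore expected to give a number near that of compound 3, with a wide range, the step of a 1.3-fold lower number from compound 3 to compound 4 (0.11 log units; within the scatter) being the estimate. Compound 4 is estimated at 25 nM, between 5 nM and 150 nM.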

Compound 4, inhibition constant: > 600 nM
Compound 4 was reported as a limit (the forecaster's own chance of this, stated with the estimate: 5%); middle value at least 24-fold (1.38 log units) from the limit.
By their numbers in this assay, from the lowest: compound 1; then compound 3; then compound 2. At a limit, above all of these: compound 4.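

Compound 4 is reported only as a limit in this assay: the limit of > 600 nM in this assay, at which 1 of the 4 values shown sits. The exchange of hydrogen for methyl on an oxygen next to a carbonyl group is a single change, and it gives an at least 400-fold higher number from compound 1 to compound 4 (2.60 log units; beyond the scatter), so the low number of the ester does not carry over to the acid. The 4-carboxyphenyl group also compares poorly with both pyridyl groups, as shown by an at least 18-fold higher number from compound 3 to compound 4 (1.27 log units; beyond the scatter) and by an at least 5.0-fold higher number from compound 2 to compound 4 (0.69 log units; beyond the scatter), so in this series a six-membered aromatic ring of carbon only, on a saturated chain carbon, six bonds along the chain from a carbonyl carbon, does not by itself give a low number: what that ring carries decides the outcome.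

As far as these compounds go, since compound 4 stands at a limit, the full size of these steps remains unknown. The compounds shown also leave open whether an ethyl ester, a primary amide or a nitrile in place of the methyl ester would keep a number close to that of compound 1 (1.5 nM), and no cause for the loss with the carboxylic acid can be drawn from them.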